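Thiourea series: the dimethylamino to diethylamino step

The compounds below may be only part of what the source reports. "The series", "measured", "known", "first", "only" and "open" are said of these compounds alone.

Measured in a functional assay for antagonist activity at Neuropeptide Y receptor type 2 (Homo sapiens); a lower number here means a stronger inhibitor, a higher number a weaker inhibitor:
Compound 1 `OC(c1ccccc1)(c1ccccc1)C1CCN(C(=S)Nc2ccc(OC(F)(F)F)cc2)CC1`: 1050 nM
Compound 2 `CCCc1ccc(NC(=S)N2CCC(C(O)(c3ccccc3)c3ccccc3)CC2)cc1`: 777 nM
Compound 3 `CN(C)c1ccc(NC(=S)N2CCC(C(O)(c3ccccc3)c3ccccc3)CC2)cc1`: 612 nM

Compound 3 stands at the low end of the three numbers, but the spread is small: a 1.3-fold lower number from compound 2 to compound 3 (0.10 log units; within the scatter) and a 1.7-fold lower number from compound 1 to compound 3 (0.23 log units; within the scatter) are both within the scatter, as is a 1.4-fold lower number from compound 1 to compound 2 (0.13 log units; within the scatter). On these numbers the three compounds are not separable in this assay.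

Compound 4 `CCN(CC)c1ccc(NC(=S)N2CCC(C(O)(c3ccccc3)c3ccccc3)CC2)cc1` differs from compound 3 in one place: diethylamino in place of dimethylamino on an aromatic carbon. The three measured steps all exchange the group on an aromatic carbon at this same position, and none of them moved this assay beyond the scatter. For the measured compounds named here, they are the only steps that bear on the change here. Going by the values given here, the new step keeps the amine and only lengthens its two alkyl arms; there is no measured precedent for an amine of a different size. The expectation is therefore no step beyond the scatter, and the estimated step of a 1.1-fold lower number from compound 3 to compound 4 (0.04 log units; within the scatter) is kept close to the value of compound 3. Compound 4 is expected to give 560 nM in this assay, with a range from 250 nM to 1300 nM.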

Compound 4, half-maximal inhibitory concentration: 72 nM
Beside the measured number, compound 4's estimate is 7.8-fold (0.89 log units) above it; the whole stated range lies above it.
By their numbers in this assay, from the lowest: compound 4; then compounds 3, 2 and 1 (each within the scatter of the next).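

Working notes on the aromatic position, para to a large group: the exchanges among trifluoromethoxy, propyl and dimethylamino stayed within the scatter, yet in this assay diethylamino gives an 8.5-fold lower number from compound 3 to compound 4 (0.93 log units; beyond the scatter) and shows that this position does respond to its substituent. The change is not tied to a single comparison, with an 11-fold lower number from compound 2 to compound 4 (1.03 log units; beyond the scatter) and a 15-fold lower number from compound 1 to compound 4 (1.16 log units; beyond the scatter) also printed as beyond the scatter, so diethylamino stands apart from all three other groups in this set. Since dimethylamino stays within the scatter of propyl and trifluoromethoxy, an amine at this position is not enough on its own to separate a compound from the others, and the measured difference comes with ethyl arms in place of methyl arms, though no measurement shown here gives a reason for the step.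

The compounds shown leave open whether the trend continues to a longer chain on the nitrogen, as in dipropylamino, or ends at diethylamino. They also leave open whether a cyclic amine such as pyrrolidine or piperidine, or an unsymmetrical ethylmethylamino group, would match diethylamino at this position.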